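A Tetrazole in Place of the Carbamoyl

The source may report more compounds than this note shows. Statements on the series, on what has been measured and on what is new or still open speak of the compounds shown alone.

Measured compounds:
compound 1 `CC(C)(C)c1ccc(C(=O)NCc2ccc(N)cc2Cl)cc1` — 46 nM
compound 2 `CC(C)(C)c1ccc(C(=O)NCc2ccc(SC(F)(F)F)cc2)cc1` — 0.4 nM
compound 3 `CC(C)(C)c1ccc(C(=O)NCc2ccc(C(N)=O)cc2)cc1` — 3800 nM

In an assay on HeLa cells with Bile acid receptor (Homo sapiens) as the target, read by a luciferase reporter, with a stated time of 24 h (a lower number here means that less compound is needed, a higher number that more compound is needed for the effect), compound 3 gives the highest number of the three; compound 1 gives 46 nM, while compound 2 gives 0.4 nM, the lowest of the set. For the measured compounds named here, the single step that reaches compound 3 is the large one, a 9500-fold higher number from compound 2 to compound 3 (3.98 log units; beyond the scatter), which exchanges a (trifluoromethyl)sulfanyl group for a carbamoyl group on an aromatic carbon.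

Compound 4 `CC(C)(C)c1ccc(C(=O)NCc2ccc(-c3nnn[nH]3)cc2)cc1` differs from compound 3 at that same aromatic carbon: 1H-tetrazol-5-yl in place of carbamoyl on an aromatic carbon. Going by the values given here, nothing measured here tells what a 1H-tetrazol-5-yl does in this place; the one step bearing on the position concerns the carbamoyl group itself, and it was large. The new group, like the carbamoyl it replaces, carries a hydrogen-bond donor and acceptors, so compound 4 is expected to stay near compound 3, with a step of a 1.3-fold higher number from compound 3 to compound 4 (0.12 log units; within the scatter) in this assay and no change beyond the scatter. The estimate for compound 4 is 5000 nM, with a range from 1500 nM to 20000 nM.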

Compound 4, half-maximal effective concentration: 120 nM
Compound 4: the middle estimate sits 42-fold (1.62 log units) above what was measured, outside the stated range (below it).
By their numbers in this assay, from the lowest: compound 2; then compound 1; then compound 4; then compound 3.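

In this assay, the step of a 32-fold lower number from compound 3 to compound 4 (1.50 log units; beyond the scatter) shows that this aromatic carbon does not treat the two groups alike, although the carbamoyl and the 1H-tetrazol-5-yl each count one hydrogen-bond donor. The 1H-tetrazol-5-yl recovers only part of what separates the carbamoyl from the (trifluoromethyl)sulfanyl group, and a 300-fold higher number from compound 2 to compound 4 (2.48 log units; beyond the scatter) still remains at the same place. No measurement at hand explains why these groups differ.

The compounds shown leave open where a carboxylic acid or a nitrile would fall at this aromatic carbon, and whether a methyl group on a tetrazole nitrogen would keep the gain. Also open, as far as these compounds go, is whether the step would hold if a cyclopropyl group took the place of the tert-butyl group in the shared core.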